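The compounds below may be only part of what the source reports. "The series", "measured", "known", "first", "only" and "open" are said of these compounds alone.

Three compounds have been measured so far in an ADME assay on BHK cells (Mesocricetus auratus) for cytotoxicity, read by MTT assay, with a stated time of 96 h; on this read-out higher numbers stand for lower toxicity in this test and lower numbers for higher toxicity in this test:

Compound 1, `Cc1ccc(NC(=S)Nc2cccc(C(F)(F)F)c2)cc1Cl`: 10000 nM
Compound 2, `O=C(NC(=S)Nc1cccc(C(F)(F)F)c1)[C@H]1C[C@@H]2CC[C@H]1C2`: 9600 nM
Compound 3, `CCOC(=O)c1ccc(NC(=S)Nc2cccc(C(F)(F)F)c2)cc1`: 50000 nM

All three share the same thiourea core carrying a trifluoromethyl-substituted aromatic ring; they differ in the group on the other side of the thiourea. On the numbers shown, compound 1 stands second highest of the three. Compound 2 gives a number so close to it that the two lie within the usual scatter of this assay, so nothing can be said about which of them is less toxic. Compound 3 stands clearly higher than compound 1, a gap that is beyond the scatter, and is therefore the least toxic of the three in this test.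

Compound 4, `Fc1ccc(NC(=S)Nc2cccc(C(F)(F)F)c2)cc1Cl`, has not yet been measured in this assay. It is built from compound 1 by a single small exchange: fluoro in place of methyl on an aromatic carbon. Among the measured compounds shown here, no pair of measured compounds differs by one such exchange, so there is no measured step to lean on. The swap keeps the ring, the chloro group and the thiourea unchanged, and exchanges one single heavy atom for another. For a move of that size, the expectation is that the step of no change at the digits printed from compound 1 to compound 4 (within the scatter) stays within the usual scatter, with no clear direction. Compound 4 is therefore expected to give about 10000 nM, within a range from 4000 nM to 25000 nM.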

Compound 4, half-maximal cytotoxic concentration: 10000 nM
Beside the measured number, compound 4's estimate shows no gap at the digits printed; the range from low to high includes it.
By their numbers in this assay, from the lowest: compounds 2, 1 and 4 (each within the scatter of the next); then compound 3.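

Among the compounds shown here, this is the first step that changes only one place, so it gives a direct reading. In this assay, for the compounds shown here, putting fluoro in place of methyl on an aromatic carbon, ortho to a chloro group and para to a large group, gives no change at the digits printed from compound 1 to compound 4 (within the scatter) and shows that this one-atom exchange at this position leaves no effect that can be told apart from the usual spread of repeated measurements, something no earlier pair of compounds could test. The data on hand offer no measurement that would explain why the two groups read alike.

Still open, going by these compounds, is whether this position would tolerate other groups equally well, such as an amine, a carboxylic acid or a longer chain, since methyl and fluoro are both single-heavy-atom groups and say little about what happens with more substantial ones. Also open, on these data alone, is whether the same exchange would read alike with the chloro group replaced, or on a compound with a different group on the other side of the thiourea.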